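The source may report more compounds than this note shows. Statements on the series, on what has been measured and on what is new or still open speak of the compounds shown alone.

Working notes on the series. Within the data shown here, the shared core carries a substituent on an amine nitrogen; compound 1 `CCCc1ccc(NC2=CC(=O)c3nc4n(c3C2=O)[C@H]2OC[C@@H](O)[C@H]2OC4)cc1` and compound 2 `O=C1C(N2CCCCC2)=CC(=O)c2c1nc1n2[C@H]2OC[C@@H](O)[C@H]2OC1` are the two measured members, compound 3 `COc1ccccc1NC1=CC(=O)c2nc3n(c2C1=O)[C@H]1OC[C@@H](O)[C@H]1OC3` is not yet measured.

In a functional assay on ECa-109 cells for inhibition, with ECa-109 cell line (Homo sapiens) as the target, read by sulforhodamine B assay (on this read-out lower numbers stand for stronger inhibition and higher numbers for weaker inhibition), compound 1 gives only the assay limit, > 4000 nM. Compound 2 likewise gives only a limit in this assay, > 8000 nM. Among the measured compounds shown here, compound 1 thus stands at a limit and not at a number (the limit of > 4000 nM in this assay, at which 1 of the 2 values shown sits), and no step between measured compounds can be computed from the two values shown.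

The change from compound 1 to compound 3 is 2-methoxyphenyl in place of 4-propylphenyl on an amine nitrogen. With both measured values sitting at limits, no step beyond the usual scatter is expected in this assay from this change, in either direction, and the outcome is most likely another limit.

Compound 3 is therefore expected to give about 5000 nM in this assay, within 1500 nM to 20000 nM, which corresponds to an estimated step that the limit leaves unreadable from compound 1 to compound 3.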

Compound 3, half-maximal inhibitory concentration: > 4000 nM
Compound 3 was reported as a limit; the forecaster's own chance of this, stated with the estimate: 60%; the middle value lies beyond the limit too.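

Among these compounds, compound 1 and compound 3 both stand at a limit in this assay, so no step between them can be read: the limit of > 4000 nM in this assay, at which 2 of the 3 values shown sit.

The compounds shown leave open whether 2-methoxyphenyl and 4-propylphenyl on the amine nitrogen differ at all in this assay; none of them gives a number there.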